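The source may report more compounds than this note shows. Statements on the series, on what has been measured and on what is new or still open speak of the compounds shown alone.

Measured compounds in a functional assay on the whole organism (strain Wistar) for inhibition, with Rattus norvegicus as the target, read by paw edema, with stated times of 30 min and 2 h, at a dose of 20 mg/kg; a lower number here means less inhibition, a higher number more inhibition at the dose given (going by the name of the read-out):
- compound 1 `CCOC(=O)C1=C(C)NC(C)=C(C(=O)OCC)C1c1ccc(OCC(=O)NNC(=O)c2sccc2Cl)cc1` gives 57.2%
- compound 2 `CCOC(=O)C1=C(C)NC(C)=C(C(=O)OCC)C1c1ccc(OCC(=O)NNC(=O)c2ccsc2Cl)cc1` gives 52.8%

Compound 2 stands at the lower of the two numbers in this assay; its nearest neighbour is compound 1, and the gap a number 4.4 percentage points lower from compound 1 to compound 2 (within the scatter) is within the scatter, so the two compounds are treated as equivalent on the numbers shown.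

The step to compound 3 `CCOC(=O)C1=C(C)NC(C)=C(C(=O)OCC)C1c1ccc(OCc2nnc(S)o2)cc1` is a different kind of change from the one measured so far: a group of 6 heavy atoms (2 carbon, 2 nitrogen, 1 oxygen, 1 sulfur; one five-membered aromatic ring with 3 hetero atoms) in place of a group of 12 heavy atoms (6 carbon, 2 nitrogen, 2 oxygen, 1 sulfur, 1 chlorine; one five-membered aromatic ring with 1 hetero atom), on a saturated chain carbon bound to an oxygen on an aromatic ring

Among the compounds with values here, the only measured step, a number 4.4 percentage points lower from compound 1 to compound 2 (within the scatter), concerns the swap of one chlorothiophene for the other on the carbonyl carbon and leaves the rest of the side chain intact. It does not bear on the removal of the whole acylhydrazide chain with its chlorothiophene and the entry of a 5-sulfanyl-1,3,4-oxadiazol-2-yl in its place, so no direction can be read from it. Within the data shown here, with no relevant step, the shared core is taken as the main carrier of the read-out and compound 3 is expected to land near compound 2, with a wide range. The step of a number 2.8 percentage points lower from compound 2 to compound 3 (within the scatter) is expected to stay within the scatter. The estimate for compound 3 in this assay is 50%, with a range from 33% to 65%.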

Compound 3, a percentage reported as inhibition, in the whole organism at one dose (the size of the read-out at that dose, not a potency): 61.7%
Estimate against measurement, compound 3: 11.7 percentage points below; measured number inside the range.
By their numbers in this assay, from the lowest: compounds 2, 1 and 3 (each within the scatter of the next).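

In this assay, the 5-sulfanyl-1,3,4-oxadiazol-2-yl on a saturated chain carbon bound to an oxygen on an aromatic ring gives a number 8.9 percentage points higher from compound 2 to compound 3 (within the scatter) and a number 4.5 percentage points higher from compound 1 to compound 3 (within the scatter) when set against the two chlorothiophene compounds. This position therefore accepts more than a swap of one chlorothiophene for the other: the whole group of 12 heavy atoms can give way to a group of 6 heavy atoms with a different five-membered aromatic ring, and the three compounds remain equivalent on these numbers. No available measurement explains why the read-out holds across this exchange.

The compounds shown leave open whether the read-out at this position needs an aromatic ring at all, or whether a short chain ending in a carboxylic acid or an amine on the same chain carbon would serve equally. They also leave open what part the sulfanyl plays, which an amino group in its place on the 1,3,4-oxadiazole would address, and every reading here remains the size of an effect at one dose, not a potency.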